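Cytotoxicity notes: pyridinyl-to-phenyl swap in the ether series

The source may report more compounds than this note shows. Statements on the series, on what has been measured and on what is new or still open speak of the compounds shown alone.

Measured so far:
compound 1 `Clc1cccc(Cl)c1Cc1nnc(Nc2ccc(COCc3cccnc3)cc2)o1` — 81000 nM
compound 2 `Fc1cccc(F)c1Cc1cnc(Nc2ccc(Oc3ccncc3)c(Cl)c2)o1` — 21000 nM

In an ADME assay on MT2 cells (Homo sapiens) for cytotoxicity, read by MTT assay (on this read-out lower numbers stand for higher toxicity in this test and higher numbers for lower toxicity in this test), compound 1 gives 81000 nM, the higher of the two numbers recorded, and compound 2 gives 21000 nM, a lower number that lies beyond the usual scatter. The two compounds differ in several places at once, so no single change can be read from that gap.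

Compound 3 `Clc1cccc(Cl)c1Cc1nnc(Nc2ccc(COCc3ccccc3)cc2)o1` is not yet measured. It keeps the whole of compound 1 apart from one change: phenyl in place of pyridin-3-yl on a saturated chain carbon bound to an oxygen on a saturated carbon. Among the measured compounds shown here, nothing among the measured compounds isolates this change, so the size of the step can only be guessed.

The expectation is a step of a 1.4-fold lower number from compound 1 to compound 3 (0.13 log units; within the scatter) from compound 1 to compound 3 in this assay that stays within the scatter, or at most a modest move towards a lower number. Compound 3 is expected to give about 60000 nM, with a plausible range of 25000 nM to 150000 nM.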

Compound 3, half-maximal cytotoxic concentration: 84000 nM
The estimate for compound 3 lay 1.4-fold (0.15 log units) below the measured number, within the range that was stated.
By their numbers in this assay, from the lowest: compound 2; then compounds 1 and 3 (each within the scatter of the next).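

On a saturated chain carbon bound to an oxygen on a saturated carbon, phenyl in place of pyridin-3-yl gives a 1.0-fold higher number from compound 1 to compound 3 (0.02 log units; within the scatter) in this assay, the only single-place comparison among the compounds shown. The nitrogen of pyridin-3-yl and the hydrogen-bond acceptor counted for that group can therefore be lost here without a shift beyond the scatter in this test. No supporting data bear on why the read-out holds at this position.

The compounds shown leave open how this assay would read with an aminomethyl group or a carboxylic acid on this terminal ring, or with a longer chain in place of (benzyloxy)methyl. Compound 2 differs from compound 1 and compound 3 in several places, so steps to it cannot be read.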